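Working notes: benzyl to phenyl on the amide nitrogen

This account rests on a few compounds, and the source may have more. Where it says the series, first, only, none or still open, it means among the compounds named here.

The set holds three compounds on one shared core. Going by the values given here, compound 1 `CC(Sc1nnc(-c2ccncc2)s1)C(=O)NCc1ccccc1Cl` is the first measured member. In an ADME assay on HepG2 cells (Homo sapiens) for cytotoxicity, with a stated time of 3 days (a higher number here means that more compound is tolerated, a lower number that less compound is tolerated), compound 1 gives > 50000 nM, which is a limit of the assay and not a number. Among the compounds with values here, the set therefore contains no measured number at all; the one value that exists is that limit (the limit of > 50000 nM in this assay, at which 1 of the 2 values shown sits).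

Compound 2 `O=C(CSc1nnc(-c2ccncc2)s1)NCc1ccccc1Cl` is the second measured member. In this assay compound 2 gives "not determined" (no result reported), so compound 2 stands nowhere on the numbers shown, and nothing can be said of where it lies relative to compound 1.

Compound 3 `O=C(CSc1nnc(-c2ccncc2)s1)Nc1ccccc1Cl` arises from compound 2 by 2-chlorophenyl in place of 2-chlorobenzyl on an amide-type nitrogen. Within the data shown here, no step of this kind has been measured in the set, so no direction can be read from the data, and no shift beyond the usual scatter in this assay is expected for this change. Compound 3 is expected to give about 60000 nM in this assay, in the range 20000 nM to 150000 nM, and most probably to be reported only as a limit again.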

Compound 3, half-maximal cytotoxic concentration: > 50000 nM
Compound 3: a limit, no number; the forecaster's own chance of this, stated with the estimate: 75%; the middle value lies beyond the limit too.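

In this assay compound 3 gives > 50000 nM, a limit and not a number. Compound 2 has no reported result, so no step can be read from compound 2 to compound 3, and compound 1 differs from neither in a readable way. Left open is whether 2-chlorophenyl and 2-chlorobenzyl on the amide-type nitrogen differ at all, and at what concentration any of these compounds becomes cytotoxic: the limit of > 50000 nM in this assay, at which 2 of the 3 values shown sit.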